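This account rests on a few compounds, and the source may have more. Where it says the series, first, only, none or still open, it means among the compounds named here.

Measured in a functional assay on HCT-116 cells (Homo sapiens) for antiproliferative activity; a higher number here means a weaker inhibitor of growth, a lower number a stronger inhibitor of growth:
- compound 1 `Cc1ccc2c(O)cc(-c3cccc(Cl)c3)nc2n1`: 25.7 nM
- compound 2 `Cc1cccc(-c2cc(O)c3ccc(C)nc3n2)c1`: 120 nM
- compound 3 `Cc1cnc2[nH]c(-c3cccc(Cl)c3)cc(=O)c2c1`: 30.2 nM

Compound 2, at 120 nM, has the highest number of the three and so is the weakest growth inhibitor among them. Compound 4 `Cc1cccc(-c2cc(O)c3c(C)cc(C)nc3n2)c1` adds one group to it: methyl in place of hydrogen on an aromatic carbon, a methyl in place of hydrogen on an aromatic carbon, opposite the ring nitrogen. Within the data shown here, the only measured step, a 4.7-fold higher number from compound 1 to compound 2 (0.67 log units; beyond the scatter), is modest and exchanges chloro for methyl. Among the measured compounds shown here, no measured step puts a methyl in place of hydrogen, so that step is only a loose guide to size, and the direction stays open. The estimated change is small, a 1.3-fold higher number from compound 2 to compound 4 (0.10 log units; within the scatter), and no clear shift beyond the scatter is expected. Compound 4 is expected at 150 nM, with an estimated range of 50 nM to 450 nM.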

Compound 4, concentration for 50% growth inhibition: 17800 nM
Estimate against measurement, compound 4: 120-fold (2.07 log units) below, and the stated range ends below it.
By their numbers in this assay, from the lowest: compounds 1 and 3 (each within the scatter of the next); then compound 2; then compound 4.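

In this assay, a single methyl in place of hydrogen on an aromatic carbon, opposite the ring nitrogen, gives a 150-fold higher number from compound 2 to compound 4 (2.17 log units; beyond the scatter), showing that this position is highly sensitive to even this small change. Among these compounds, the only earlier step, a 4.7-fold higher number from compound 1 to compound 2 (0.67 log units; beyond the scatter), was a modest one that exchanged chloro for methyl at another place. No measurement shown explains the large loss of growth inhibition.

From the compounds shown here alone, it remains open how a fluoro, a hydroxyl or an amine at this position would behave. Going by these compounds, it is also open whether the same methyl would cost as much in compound 1, which carries chloro.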